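From pyridin-3-yl to pyridin-4-yl: what to expect

The compounds below may be only part of what the source reports. "The series", "measured", "known", "first", "only" and "open" are said of these compounds alone.

Measured in an ADME assay on HepG2 cells (Homo sapiens) for cytotoxicity, read by MTT assay, with a stated time of 48 h; on this read-out lower numbers stand for stronger inhibition and higher numbers for weaker inhibition:
- compound 1 `Cc1ccc(-c2ccc(CNCCCNc3ccnc4cc(Cl)ccc34)s2)cc1`: 1290 nM
- compound 2 `COc1ccc(-c2ccc(CNCCCNc3ccnc4cc(Cl)ccc34)s2)cc1`: 2230 nM
- compound 3 `Clc1ccc2c(NCCCNCc3ccc(-c4cccnc4)s3)ccnc2c1`: 21600 nM

Of these three, compound 3 has the highest number, 21600 nM, and so shows the weakest inhibition. The next molecule, compound 4 `Clc1ccc2c(NCCCNCc3ccc(-c4ccncc4)s3)ccnc2c1`, has the same atoms as compound 3, joined differently: pyridin-4-yl in place of pyridin-3-yl on an aromatic carbon. Here, pyridin-4-yl takes the place of pyridin-3-yl on an aromatic carbon, next to the ring sulfur.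

Within the data shown here, two measured steps bear on this change, both bringing in pyridin-3-yl. One is large, a 17-fold higher number from compound 1 to compound 3 (1.22 log units; beyond the scatter), and the other modest, a 9.7-fold higher number from compound 2 to compound 3 (0.99 log units; beyond the scatter). By contrast, a 1.7-fold higher number from compound 1 to compound 2 (0.24 log units; within the scatter) stays within the scatter. Neither of the first two steps exchanges one pyridinyl group for another, so the data give no direct measure of this change. Since compound 4 also carries a pyridinyl group, it is expected to stay close to compound 3 at 21600 nM. The expected result is a 1.2-fold lower number from compound 3 to compound 4 (0.08 log units; within the scatter), so no step beyond the scatter is expected in this assay. For compound 4 the estimated value is 18000 nM, with an expected range of 8000 nM to 40000 nM.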

Compound 4, half-maximal inhibitory concentration: 3320 nM
For compound 4 the middle estimate is 5.4-fold (0.73 log units) above the measured one, outside the stated range (below it).
By their numbers in this assay, from the lowest: compounds 1, 2 and 4 (each within the scatter of the next, the first and the last beyond it); then compound 3.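

In this assay, pyridin-4-yl in place of pyridin-3-yl on this aromatic carbon, next to the ring sulfur, gives a real change (a 6.5-fold lower number from compound 3 to compound 4 (0.81 log units; beyond the scatter)); the two groups have the same atoms, so how they are joined matters here, and carrying a pyridinyl group does not by itself set the number. Compound 4 also stays within the scatter of the 4-methoxyphenyl compound (a 1.5-fold higher number from compound 2 to compound 4 (0.17 log units; within the scatter)) but not of the 4-methylphenyl compound (a 2.6-fold higher number from compound 1 to compound 4 (0.41 log units; beyond the scatter)), so among these compounds the high number belongs to compound 3, not to pyridinyl groups in general. Nothing available here explains the difference between the two pyridinyl groups.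

Where pyridin-2-yl would fall at this place remains open. So does whether the same change would carry over to compounds with a longer chain between the core and the sulfur ring.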